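The source may report more compounds than this note shows. Statements on the series, on what has been measured and on what is new or still open speak of the compounds shown alone.

In an ADME assay on S9 fraction from liver (Rattus norvegicus) for metabolic stability, with a stated time of 1 h (a lower number here means that less of the compound is left, a higher number that more of the compound is left), compound 1 (`CO[C@H]1CC[C@@H](Nc2cc(NCc3cnccc3C(F)(F)F)ncc2C#N)CC1`) gives 1%, which places it at the bottom of the three measured numbers, level within the scatter with compound 2 (`CO[C@H]1CC[C@@H](CNc2cc(NCc3cnccc3C(F)(F)F)ncc2C#N)CC1`) at 2%. Compound 3 (`N#Cc1cnc(NCc2cnccc2C(F)(F)F)cc1NC1CCOCC1`) stands clear of both at 17%. Compound 4 (`N#Cc1cnc(NCc2cnccc2C(F)(F)F)cc1N[C@H]1CC[C@@H](c2nc[nH]n2)CC1`) has not yet been measured. Its difference from compound 1 is this: 1H-1,2,4-triazol-3-yl in place of methoxy on a saturated ring carbon. In short, 1H-1,2,4-triazol-3-yl stands in place of methoxy on a saturated ring carbon.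

For the measured compounds named here, no measured step makes this exchange, so the guidance is indirect. The steps available alter the whole group on the nitrogen: one gives a number 1 percentage points higher from compound 1 to compound 2 (within the scatter), and the other gives a number 16 percentage points higher from compound 1 to compound 3 (beyond the scatter). Going by the values given here, the second is the only step beyond the scatter that starts from compound 1, and it is modest. Compound 1, at 1%, also has almost no room to fall in this assay. A modest upward change is therefore expected, estimated as a number 11 percentage points higher from compound 1 to compound 4 (beyond the scatter). For compound 4 the estimated value is 12%, with an expected range of 2% to 35%.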

Compound 4, percent of the compound remaining: 29%
The estimate for compound 4 lay 17 percentage points below the measured number; low and high end bracket the measured number.
By their numbers in this assay, from the lowest: compounds 1 and 2 (each within the scatter of the next); then compound 3; then compound 4.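

Putting 1H-1,2,4-triazol-3-yl in place of methoxy on a saturated ring carbon gives a number 28 percentage points higher from compound 1 to compound 4 (beyond the scatter) in this assay. The earlier steps shown here each replaced the whole group on the nitrogen, whereas this one keeps the six-membered non-aromatic ring of carbon only and changes just the group three ring bonds from the ring atom that bears a large group. A change at this carbon alone therefore moves the number beyond the scatter, but nothing available accounts for the step.

The compounds shown leave open whether this result is particular to the triazole or would also hold for an amine or a carboxylic acid on the same carbon. They also leave open how a methyl group on a triazole nitrogen would read in this assay.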